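Swapping the Amide Substituent in a Triazole Series

This account rests on a few compounds, and the source may have more. Where it says the series, first, only, none or still open, it means among the compounds named here.

For the measured compounds named here, compound 2 `CCOC(=O)C1=Cc2ccccc2OC1(OCc1cn(CC(=O)NC2CCCCC2)nn1)C(F)(F)F` is one of two compounds measured in a functional assay on MCF7 cells (Homo sapiens) for inhibition, read by MTT assay, with a stated time of 24 h; a lower number here means a stronger inhibitor, a higher number a weaker inhibitor. Compound 2 gives 12100 nM, the higher of the two numbers, though its nearest neighbour, compound 1 `CCOC(=O)C1=Cc2ccccc2OC1(OCc1cn(CC(=O)Nc2cccc(Cl)c2)nn1)C(F)(F)F`, gives 11600 nM, and the two lie within the scatter of each other. They share the same core and differ only in the group on the amide-type nitrogen, a cyclohexyl in compound 2 against a 3-chlorophenyl in compound 1.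

The unmeasured compound 3 `CCOC(=O)C1=Cc2ccccc2OC1(OCc1cn(CC(=O)Nc2ccc(C)cc2)nn1)C(F)(F)F` differs from compound 2 by 4-methylphenyl in place of cyclohexyl on an amide-type nitrogen. Going by the values given here, the only measured step that bears on this change is the one between compound 1 and compound 2, where a saturated ring replaced an aromatic one on the same nitrogen; the present change brings an aromatic ring back in place of the saturated one. Because a 1.0-fold higher number from compound 1 to compound 2 (0.02 log units; within the scatter) stayed within the scatter, no shift beyond the scatter is expected in this assay, and the expected step is a 1.1-fold lower number from compound 2 to compound 3 (0.04 log units; within the scatter). Compound 3 is therefore estimated at 11000 nM, with a range from 5000 nM to 25000 nM.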

Compound 3, half-maximal inhibitory concentration: > 150000 nM
Compound 3: a limit, no number; the forecaster's own chance of this, stated with the estimate: 10%; middle value at least 13-fold (1.13 log units) away from the limit.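

Compound 3 gives a limit in this assay, not a number: the limit of > 150000 nM in this assay, at which 1 of the 3 values shown sits.

The group on this amide-type nitrogen therefore matters far more than the first two compounds suggested, since 4-methylphenyl in place of cyclohexyl gives an at least 12-fold higher number from compound 2 to compound 3 (1.09 log units; beyond the scatter), and 4-methylphenyl in place of 3-chlorophenyl gives an at least 12-fold higher number from compound 1 to compound 3 (1.11 log units; beyond the scatter). Compound 1 also carries a six-membered aromatic ring on this nitrogen, so an aromatic ring as such does not go with the loss of activity; what separates compound 1 from compound 3 is the change from 3-chlorophenyl to 4-methylphenyl.

The compounds shown cannot tell whether the methyl group, its place on the ring or the absence of the chlorine drives this step, and plain phenyl, 4-chlorophenyl and 3-methylphenyl are the groups that would pull these apart. Going by these compounds, with a limit in place of a number, the true size of both steps also stays open.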